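From pyrrolidin-1-yl to 4-methylpiperazin-1-yl on a shared core

This account rests on a few compounds, and the source may have more. Where it says the series, first, only, none or still open, it means among the compounds named here.

- Compound 1 `COc1cc(OC)c2c(=O)c(OCCCCN3CCCC3)c(-c3cc(OC)c(OC)c(OC)c3)oc2c1`: 18600 nM
- Compound 2 `COc1cc(OC)c2c(=O)c(OCCCCN3CCCCC3)c(-c3cc(OC)c(OC)c(OC)c3)oc2c1`: 26800 nM

Both numbers come from a functional assay on MGC-803 cells (Homo sapiens) for cytotoxicity, read by MTT assay, with a stated time of 38 h; on this read-out higher numbers stand for weaker inhibition and lower numbers for stronger inhibition. Only these two compounds have been measured so far, and the comparison between them reads a 1.4-fold higher number from compound 1 to compound 2 (0.16 log units; within the scatter). Compound 1 therefore stands level with compound 2, since repeat measurements of one compound could differ this much.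

Compound 3 `COc1cc(OC)c2c(=O)c(OCCCCN3CCN(C)CC3)c(-c3cc(OC)c(OC)c(OC)c3)oc2c1` keeps the shared core and changes one group: 4-methylpiperazin-1-yl in place of pyrrolidin-1-yl on a saturated chain carbon, four bonds along the chain from an oxygen on an aromatic ring. For the measured compounds named here, the only measured step that bears on this change replaced pyrrolidin-1-yl at the same place, with piperidin-1-yl as the new group. That step, a 1.4-fold higher number from compound 1 to compound 2 (0.16 log units; within the scatter), stayed within the scatter. Going by the values given here, it is a single step, however, and no measured compound carries 4-methylpiperazin-1-yl, so it is only a loose guide. No step beyond the scatter is expected in this assay, in either direction, although the uncertainty is wide. Compound 3 is expected at 22000 nM, with an estimated range of 9000 nM to 55000 nM. The expected change is a 1.2-fold higher number from compound 1 to compound 3 (0.07 log units; within the scatter).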

Compound 3, half-maximal inhibitory concentration: 12200 nM
The estimate for compound 3 lay 1.8-fold (0.26 log units) above the measured number, and the stated range covers the measured number.
By their numbers in this assay, from the lowest: compounds 3, 1 and 2 (each within the scatter of the next, the first and the last beyond it).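

In this assay this position now gives its first step beyond the scatter, a 2.2-fold lower number from compound 2 to compound 3 (0.34 log units; beyond the scatter), a modest step in which 4-methylpiperazin-1-yl replaces piperidin-1-yl on the same chain. The replacement of pyrrolidin-1-yl by the same group gives a 1.5-fold lower number from compound 1 to compound 3 (0.18 log units; within the scatter), so these two groups cannot be told apart here. For the compounds shown here, only the pair of six-membered rings, compound 2 and compound 3, is separated by more than the scatter. The size of that separation is small, and no measurement on hand gives a reason for it.

Going by these compounds, with so few groups, it remains open whether the gap between the two six-membered rings reflects the second ring nitrogen or the methyl group on it, a question that a piperazin-1-yl group without the methyl, or a morpholin-4-yl group with oxygen in place of that nitrogen, could help to settle. On these data alone, it is also open whether the same ordering would hold on a shorter chain, such as 3-(4-methylpiperazin-1-yl)propyl, or whether an open-chain dimethylamino group would fall within the same range.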